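Amide nitrogen substituents on a shared chromone acrylamide core

The source may report more compounds than this note shows. Statements on the series, on what has been measured and on what is new or still open speak of the compounds shown alone.

Measured in a functional assay on HeLa cells (Homo sapiens) for inhibition, read by MTT assay, with a stated time of 48 h; on this read-out lower numbers stand for stronger inhibition and higher numbers for weaker inhibition:
compound 1 `COc1ccc2c(=O)c(/C=C/C(=O)NCc3ccccc3)coc2c1`: 33400 nM
compound 2 `COc1ccc2c(=O)c(/C=C/C(=O)Nc3ccccc3C)coc2c1`: 7270 nM
compound 3 `COc1ccc2c(=O)c(/C=C/C(=O)Nc3ccc(F)cc3)coc2c1`: 9680 nM

Compound 3 sits second highest of the three numbers; its nearest neighbour is compound 2, with a 1.3-fold higher number from compound 2 to compound 3 (0.12 log units; within the scatter), and its furthest is compound 1, with a 3.5-fold lower number from compound 1 to compound 3 (0.54 log units; beyond the scatter). Going by the values given here, the only other step in the set is a 4.6-fold lower number from compound 1 to compound 2 (0.66 log units; beyond the scatter). Both steps beyond the scatter swap a benzyl for an aryl group on the amide-type nitrogen; the step between the two aryl compounds stays within the scatter.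

Compound 4 `CCOc1ccc(NC(=O)/C=C/c2coc3cc(OC)ccc3c2=O)cc1` keeps the aryl amide of compound 3 and changes only the substituent on it: ethoxy in place of fluoro on an aromatic carbon. Among the compounds with values here, no measured step exchanges one group for another at this place on the aryl ring, so the only guide is that the two aryl compounds 2 and 3 lie within the scatter of each other. The expected step in this assay is therefore small, with no direction supported beyond the scatter. Compound 4 is estimated at 9000 nM, with a range from 3000 nM to 27000 nM. The expected step is thus a 1.1-fold lower number from compound 3 to compound 4 (0.03 log units; within the scatter).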

Compound 4, half-maximal inhibitory concentration: > 100000 nM
Compound 4: only a limit was reported; the forecaster's own chance of this, stated with the estimate: 5%; at least 11-fold (1.04 log units) between middle value and limit.
By their numbers in this assay, from the lowest: compounds 2 and 3 (each within the scatter of the next); then compound 1. At a limit, above all of these: compound 4.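

In this assay, compound 4 gives only a limit of the assay, not a number: the limit of > 100000 nM in this assay, at which 1 of the 4 values shown sits. This is the first exchange shown on an aromatic carbon para to a large group, and it is not neutral: an at least 10-fold higher number from compound 3 to compound 4 (1.01 log units; beyond the scatter), although compounds 2 and 3 lie within the scatter of each other. The aryl amide alone therefore does not keep the number low, as an at least 13-fold higher number from compound 2 to compound 4 (1.13 log units; beyond the scatter) and an at least 2.9-fold higher number from compound 1 to compound 4 (0.47 log units; beyond the scatter), so compound 4 goes against the earlier contrast of aryl with benzyl.

Going by these compounds, whether this step belongs to ethoxy alone or extends to other groups at this place remains open; methoxy, hydroxyl or an amine there would help separate these cases. On these data alone, the true size of the step also remains open while compound 4 stands at a limit.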